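The source may report more compounds than this note shows. Statements on the series, on what has been measured and on what is new or still open speak of the compounds shown alone.

Measured compounds:
- compound 1 `CC(=O)OCc1ccc2oc(=O)c(C(=O)Oc3cccc(Cl)c3)cc2c1`: 49.1%
- compound 2 `NCc1ccc2oc(=O)c(C(=O)Oc3cccc(Cl)c3)cc2c1`: 86.6%

In a functional assay on HT-1080 cells (Homo sapiens), read by transwell migration, with a stated time of 24 h, tested at 1 uM (on this read-out lower numbers stand for a stronger effect and higher numbers for a weaker effect at the one concentration tested), compound 2 gives the highest of the two numbers, the weaker effect; compound 1 gives the lower number. Among the measured compounds shown here, the only measured step, a number 37.5 percentage points higher from compound 1 to compound 2 (beyond the scatter), shows that a change at the saturated chain carbon bound to an aromatic carbon moves this assay strongly. Compound 3 `Cc1ccc2oc(=O)c(C(=O)Oc3cccc(Cl)c3)cc2c1` carries hydrogen in place of amino on a saturated chain carbon bound to an aromatic carbon. For the measured compounds named here, no measured step covers this exact change, so the direction is uncertain; a step of some size, in either direction, is plausible. Compound 3 is expected to show a lower number than compound 2, a number 24.6 percentage points lower from compound 2 to compound 3 (beyond the scatter), estimated at 62% with a range of 35% to 90%.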

Compound 3, a percentage reported as activity, at one concentration (the size of the read-out at that concentration, not a potency): 52.5%
Beside the measured number, compound 3's estimate is 9.5 percentage points above it, and the stated range covers the measured number.
By their numbers in this assay, from the lowest: compounds 1 and 3 (each within the scatter of the next); then compound 2.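

In this assay, hydrogen in place of amino gives a number 34.1 percentage points lower from compound 2 to compound 3 (beyond the scatter), so among these three compounds the higher number goes with the aminomethyl group and not with the shared core. Hydrogen in place of acetoxy on the same saturated chain carbon gives a number 3.4 percentage points higher from compound 1 to compound 3 (within the scatter), so these two groups read alike here. Nothing available explains this difference.

As far as these compounds go, whether a hydroxymethyl group or a carboxylic acid at this carbon would read with compound 3 or with compound 2 stays open. So does the reading of a longer chain or a dimethylamino group there.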